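Amide nitrogen substituents: from compound 3 to compound 4

The source may report more compounds than this note shows. Statements on the series, on what has been measured and on what is new or still open speak of the compounds shown alone.

Measured in a functional assay on SK-OV-3 cells (Homo sapiens) for antiproliferative activity, read by MTT assay, with a stated time of 72 h; a lower number here means a stronger inhibitor, a higher number a weaker inhibitor:
- compound 1 `CCNC(=O)CCc1cccc2c1B(O)OC2`: > 100000 nM (a limit)
- compound 2 `O=C(CCc1cccc2c1B(O)OC2)Nc1ccccc1`: 200 nM
- compound 3 `O=C(CCc1cccc2c1B(O)OC2)NCc1ccccc1`: > 100000 nM (a limit)

Compound 3 stands at the limit of > 100000 nM in this assay, at which 2 of the 3 values shown sit. Its reading is a limit and not a number.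

Compound 4 `O=C(CCc1cccc2c1B(O)OC2)Nc1ccc(F)cc1` is not yet measured. It has 4-fluorophenyl in place of benzyl on an amide-type nitrogen.

For the measured compounds named here, two measured steps bear on this change. The closest is an at least 500-fold higher number from compound 2 to compound 3 (2.69 log units; beyond the scatter), with benzyl in place of phenyl on an amide-type nitrogen. The other is an at least 500-fold lower number from compound 1 to compound 2 (2.69 log units; beyond the scatter), with phenyl in place of ethyl at that nitrogen. Both are large. Going by the values given here, compound 4 carries 4-fluorophenyl where compound 2 carries phenyl, and no measured step covers that exchange.

A large step toward a lower number is therefore expected in this assay, reversing an at least 500-fold higher number from compound 2 to compound 3 (2.69 log units; beyond the scatter). The expected step is an at least 330-fold lower number from compound 3 to compound 4 (2.52 log units; beyond the scatter). For compound 4 the estimated value is 300 nM, with an expected range of 40 nM to 3000 nM.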

Compound 4, half-maximal inhibitory concentration: 720 nM
Beside the measured number, compound 4's estimate is 2.4-fold (0.38 log units) below it, within the range that was stated.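

In this assay, 4-fluorophenyl on the amide-type nitrogen keeps the large gain seen with phenyl: 4-fluorophenyl in place of benzyl gives an at least 130-fold lower number from compound 3 to compound 4 (2.14 log units; beyond the scatter), and 4-fluorophenyl in place of ethyl gives an at least 130-fold lower number from compound 1 to compound 4 (2.14 log units; beyond the scatter). Fluoro in place of hydrogen on an aromatic carbon is the first change shown on this ring itself, and it gives a 3.6-fold higher number from compound 2 to compound 4 (0.56 log units; beyond the scatter), a modest loss beyond the scatter that leaves far more of the gain intact than benzyl does. Compound 1 and compound 3 remain limits and not numbers, so both large steps are bounds only: the limit of > 100000 nM in this assay, at which 2 of the 4 values shown sit.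

Going by these compounds, what a chloro or methoxy group gives in place of fluoro stays open, as does the effect of an amine on the same ring. The compounds shown also leave open how a longer chain from the carbonyl to the shared core would read.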